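The compounds below may be only part of what the source reports. "The series", "measured", "known", "first", "only" and "open" are said of these compounds alone.

The measured compounds, all in a functional assay on HCT-116 cells (Homo sapiens) for inhibition, read by MTT assay, with a stated time of 48 h; on this read-out lower numbers stand for stronger inhibition and higher numbers for weaker inhibition:

compound 1, `COc1cc(NCc2ccccc2)cc(OC)c1OC`; in this assay compound 1 gives > 80000 nM, which is a limit of the assay rather than a number.
compound 2, `COc1cc(NCc2cccc(O)c2)cc(OC)c1OC`; compound 2 gives 67700 nM.
compound 3, `C/C=C/C(=O)N(Cc1ccc(OC)c(O)c1)c1cc(OC)c(OC)c(OC)c1`; compound 3 gives 55 nM.

Compound 2 and compound 1 share a core and differ in one place: hydrogen in place of hydroxy on an aromatic carbon. This change made an at least 1.1-fold higher number from compound 2 to compound 1 (0.07 log units; that floor lies within the scatter). Because compound 1 sits at the limit of > 80000 nM in this assay, at which 1 of the 3 values shown sits, that step is only a floor, and nothing more can be read from it. Compound 3 stands apart from both: the difference between the core of compound 3 and that of compound 2 is not broken down here, and the two values simply show that compound 3 gives a far lower number than compound 2.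

Compound 4, `C/C=C/C(=O)N(Cc1ccc(OC)cc1)c1cc(OC)c(OC)c(OC)c1`, is not yet measured. It differs from compound 3 in one place: hydrogen in place of hydroxy on an aromatic carbon. This is the same kind of change as that from compound 2 to compound 1, but not the same: in compound 3 the hydroxy is ortho to a methoxy group and meta to a large group, whereas in compound 2 it is only meta to a large group.

Among the measured compounds shown here, the step is expected to be a 5.5-fold higher number from compound 3 to compound 4 (0.74 log units; beyond the scatter), a modest loss, since the only measured instance of this change, an at least 1.1-fold higher number from compound 2 to compound 1 (0.07 log units; that floor lies within the scatter), gives a floor that lies within the scatter. The number for compound 3, 55 nM, leaves ample room for a higher value. Compound 4 is therefore estimated at 300 nM, most likely between 80 nM and 2000 nM.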

Compound 4, half-maximal inhibitory concentration: 500 nM
The estimate for compound 4 lay 1.7-fold (0.22 log units) below the measured number, within the range that was stated.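

On the core of compound 3 in this assay, hydrogen in place of hydroxy, which turns 3-hydroxy-4-methoxyphenyl into 4-methoxyphenyl, gave a 9.1-fold higher number from compound 3 to compound 4 (0.96 log units; beyond the scatter). This shows that the change can carry a clear cost on one core, but it does not show whether the same cost carries over to the other core, and the two steps can be neither equated nor separated: the same change on two cores in this assay, an at least 1.1-fold higher number (0.07 log units; that floor lies within the scatter) from compound 2 to compound 1 and a 9.1-fold higher number (0.96 log units; beyond the scatter) from compound 3 to compound 4; the limit leaves it open whether they differ. The step on the core of compound 2 can be read only as a floor, since compound 1 stands at a limit of the assay rather than at a number: the limit of > 80000 nM in this assay, at which 1 of the 4 values shown sits.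

The compounds shown leave open whether an amine, a fluorine or a carboxylic acid in the place of the hydroxy would give a number nearer that of compound 3 or that of compound 4. Among the compounds shown here, they also leave open how much of the wide gap between the two cores belongs to the acyl part of compound 3, as no pair here changes that part alone, and an acetyl group or a longer chain there would be needed to tell.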